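A few compounds are considered here, and "the series" means these few. Any claim that something is new, unique, unknown or untested is made for them only; others in the source may bear on it.

Of the compounds shown here, three built on one shared core have so far been measured in a functional assay, read by spectrophotometry, tested at 100 uM; on this read-out higher numbers stand for weaker inhibition and lower numbers for stronger inhibition. Compound 1 `Cc1ccc(/C=C/C(=O)c2cccc(NC(=O)c3cc(-c4ccncc4)n[nH]3)c2)cc1` gives 64600 nM. Compound 2 `O=C(/C=C/c1ccc(Cl)cc1)c1cccc(NC(=O)c2cc(-c3ccncc3)n[nH]2)c1` gives 78900 nM, the highest of the three numbers shown, although its gaps to both other compounds are within the scatter. Compound 3 `O=C(/C=C/c1ccc([N+](=O)[O-])cc1)c1cccc(NC(=O)c2cc(-c3ccncc3)n[nH]2)c1` gives 64600 nM. The measured steps, a 1.2-fold higher number from compound 1 to compound 2 (0.09 log units; within the scatter), no change at the digits printed from compound 1 to compound 3 (within the scatter) and a 1.2-fold lower number from compound 2 to compound 3 (0.09 log units; within the scatter), each exchange a single group on an aromatic carbon of the shared core, and none of them moves the number beyond the scatter.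

Compound 4 `O=C(/C=C/c1ccc(Cl)cc1Cl)c1cccc(NC(=O)c2cc(-c3ccncc3)n[nH]2)c1` has not yet been measured. It differs from compound 2 by chloro in place of hydrogen on an aromatic carbon. Among the compounds with values here, no measured step adds a second chloro group, so the closest guidance comes from the single-group exchanges already described: chloro in place of methyl, nitro in place of methyl and nitro in place of chloro, all within the scatter. Since three such exchanges on an aromatic carbon left the read-out essentially unchanged, the step expected from compound 2 to compound 4 is no change at the digits printed from compound 2 to compound 4 (within the scatter), that is, nothing beyond the scatter. Compound 4 is therefore estimated at 78900 nM, with a range from 35000 nM to 170000 nM.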

Compound 4, half-maximal inhibitory concentration: 80900 nM
Beside the measured number, compound 4's estimate is 1.0-fold (0.01 log units) below it, and the stated range covers the measured number.
By their numbers in this assay, from the lowest: compounds 1, 3, 2 and 4 (each within the scatter of the next).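

Within the data shown here, until now this ring carried a single group, and the only change was swapping that group for another. The 2,4-dichlorophenyl ring instead adds a chloro on an aromatic carbon ortho to a large group and meta to the existing chloro group, and in this assay that addition gives a 1.0-fold higher number from compound 2 to compound 4 (0.01 log units; within the scatter) and so leaves the read-out within the scatter. Against the rings with one group the result is the same: the change from 4-nitrophenyl gives a 1.3-fold higher number from compound 3 to compound 4 (0.10 log units; within the scatter) and the change from 4-methylphenyl gives a 1.3-fold higher number from compound 1 to compound 4 (0.10 log units; within the scatter) so at this position a second group on the ring, at least when it is chloro, does not move the number beyond the scatter, and nothing measured here says why.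

The groups shown on this ring are only methyl, chloro and nitro, so whether an amine, a carboxylic acid or a longer chain would shift the number beyond the scatter stays open. From the compounds shown here alone, the added chloro also appears only alongside the other chloro group, so how it reads on a ring without that group remains unknown.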